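This account rests on a few compounds, and the source may have more. Where it says the series, first, only, none or still open, it means among the compounds named here.

Of the compounds shown here, three have so far been measured in a functional assay on the whole organism (strain Wistar albino) for inhibition, with Rattus norvegicus as the target, read by paw edema, with stated times of 1 h and 3 h, at a dose of 0.32 mmol/kg by the intraperitoneal route; on this read-out higher numbers stand for more inhibition at the one dose given (going by the name of the read-out) and lower numbers for less inhibition. Compound 1 `Cc1ccc(-c2nn(-c3ccc(Cl)cc3)cc2/C=N\c2ccc(Cl)cc2)cc1` gives 49.2%, and compound 2 `COc1ccc(-c2nn(-c3ccc(Cl)cc3)cc2/C=N\c2ccc(Cl)cc2)cc1` gives 72.6%. These two differ only by methoxy in place of methyl on an aromatic carbon and that change gave a number 23.4 percentage points higher from compound 1 to compound 2 (beyond the scatter). Compound 3 `Cc1ccc(-c2nn(-c3ccc(S(N)(=O)=O)cc3)cc2/C=C\C(=O)c2ccc(Cl)cc2)cc1` rests on a different core; how its core differs from that of compound 1 is not broken down here. In this assay compound 3 gives 47.6%, a number within the scatter of compound 1. Compound 4 `COc1ccc(-c2nn(-c3ccc(S(N)(=O)=O)cc3)cc2/C=C\C(=O)c2ccc(Cl)cc2)cc1` has not been measured; it differs from compound 3 by methoxy in place of methyl on an aromatic carbon, the same change as between compound 1 and compound 2, at a place described in the same words. Because a number 23.4 percentage points higher from compound 1 to compound 2 (beyond the scatter) was modest and seen on another core, the expected step is a number 15.4 percentage points higher from compound 3 to compound 4 (beyond the scatter), somewhat smaller and less certain. Compound 4 is accordingly estimated at 63%, with a likely range from 46% to 78%.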

Compound 4, a percentage reported as inhibition, in the whole organism at one dose (the size of the read-out at that dose, not a potency): 56%
Estimate against measurement, compound 4: 7 percentage points above; the measured number falls inside the stated range.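

In this assay, methoxy in place of methyl gave a number 8.4 percentage points higher from compound 3 to compound 4 (within the scatter), so on this core the step cannot be told apart from repeat scatter. Among the compounds shown here, the change therefore does not carry over at the same size from one core to the other: the same change on two cores in this assay, a number 23.4 percentage points higher (beyond the scatter) from compound 1 to compound 2 and a number 8.4 percentage points higher (within the scatter) from compound 3 to compound 4, 15 percentage points apart, beyond the scatter of two such steps With only two pairs, this does not show which feature of the two cores accounts for the gap, nor that the change would behave the same way on any further core.

The compounds shown leave open what other groups at this place would do, such as an amine, a hydroxyl or a longer chain like ethoxy. They also leave open how the step would look at doses other than the single one tested.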